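The source may report more compounds than this note shows. Statements on the series, on what has been measured and on what is new or still open speak of the compounds shown alone.

Measured compounds:
Compound 1 `C=CCc1cc(C(C)=O)c(O)cc1OCCCC#N`: 6%
Compound 2 `C=CCc1cc(C(C)=O)c(O)cc1OCCCCC#N`: 57%
Compound 3 `C=CCc1cc(C(C)=O)c(O)cc1OCCCCCCCC#N`: 52%

In an assay on isolated protein for binding affinity to leukotriene B4 receptor 1 (Homo sapiens), tested at 1 uM (on this read-out lower numbers stand for less inhibition and higher numbers for more inhibition at the one concentration tested (going by the name of the read-out)), compound 3 stands second highest of the three numbers; compound 2 lies above it by a margin inside the scatter, while compound 1 sits far below, as the step of a number 46 percentage points higher from compound 1 to compound 3 (beyond the scatter) shows. Compound 4 `C=CCc1cc(C(C)=O)c(O)cc1OCCCC` differs from compound 3 by hydrogen in place of 3-cyanopropyl on a saturated chain carbon, four bonds along the chain from an oxygen on an aromatic ring. Going by the values given here, no measured step removes the cyano group outright. The closest guides are a number 51 percentage points higher from compound 1 to compound 2 (beyond the scatter) and a number 46 percentage points higher from compound 1 to compound 3 (beyond the scatter), both large rises that came with longer cyano chains, whereas a number 5 percentage points lower from compound 2 to compound 3 (within the scatter) stayed within the scatter. Compound 4, which keeps no cyano at all, is therefore expected to drop back toward the level of compound 1. For compound 4 a step of a number 30 percentage points lower from compound 3 to compound 4 (beyond the scatter) is expected, giving an estimated 22% with a range from 3% to 50%.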

Compound 4, a percentage reported as inhibition, at one concentration (the size of the read-out at that concentration, not a potency): 8%
For compound 4 the middle estimate is 14 percentage points above the measured one, and the stated range covers the measured number.
By their numbers in this assay, from the lowest: compounds 1 and 4 (each within the scatter of the next); then compounds 3 and 2 (each within the scatter of the next).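

In this assay, taking the nitrile off the longer chains removes most of the signal (a number 44 percentage points lower from compound 3 to compound 4 (beyond the scatter)) (a number 49 percentage points lower from compound 2 to compound 4 (beyond the scatter)). The plain chain of compound 4 gives no clear difference from the short nitrile chain of compound 1 (a number 2 percentage points higher from compound 1 to compound 4 (within the scatter)). Among these four compounds, then, neither the short nitrile chain nor the plain chain reaches the numbers of compound 2 and compound 3, which pair a nitrile with a longer chain.

As far as these compounds go, whether an amine or a carboxylic acid at the chain end could stand in for the nitrile remains open, as does the result for a longer plain chain. Nothing available explains why the nitrile matters here.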